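Benzylamine Cinnamide Anilides Against a Colon Cancer Line

The source may hold more compounds than are shown below. What is called first, only, known or untested is meant among the compounds shown, and "the series" means these compounds.

Compound 3 `Nc1ccccc1NC(=O)/C=C/c1ccc(NCc2ccncc2)cc1` gives the lowest of the three numbers recorded in a functional assay on HCT-116 cells (Homo sapiens) for antiproliferative activity, read by MTT assay; a higher number here means a weaker inhibitor, a lower number a stronger inhibitor: compound 3 shows 2000 nM. Compound 2 `Nc1ccccc1NC(=O)/C=C/c1ccc(CNc2ccccc2)cc1` gives 11000 nM, and compound 1 `COc1ccc(CNc2ccc(/C=C/C(=O)Nc3ccccc3N)cc2)cc1` gives 37000 nM. Both a 5.5-fold lower number from compound 2 to compound 3 (0.74 log units; beyond the scatter) and a 19-fold lower number from compound 1 to compound 3 (1.27 log units; beyond the scatter) fall beyond the scatter. Compound 4 `Nc1ccccc1NC(=O)/C=C/c1ccc(NCc2ccc([N+](=O)[O-])cc2)cc1` differs from compound 3 by a single exchange, (4-nitrophenyl in place of pyridin-4-yl on a saturated chain carbon bound to a nitrogen on an aromatic ring). Of the measured steps, only a 19-fold lower number from compound 1 to compound 3 (1.27 log units; beyond the scatter) bears directly on this exchange, since that step also swaps the pyridin-4-yl ring for a substituted phenyl ring, and it was large. Compound 4 is therefore expected to give an upward step of a 4.0-fold higher number from compound 3 to compound 4 (0.60 log units; beyond the scatter). That would place compound 4 between compound 3 and compound 1. The estimate for compound 4 is 8000 nM, with a range from 2500 nM to 25000 nM.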

Compound 4, half-maximal inhibitory concentration: 15000 nM
The estimate for compound 4 lay 1.9-fold (0.27 log units) below the measured number; measured number inside the range.
By their numbers in this assay, from the lowest: compound 3; then compounds 2 and 4 (each within the scatter of the next); then compound 1.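

In this assay, the exchange of pyridin-4-yl for 4-nitrophenyl on this saturated chain carbon, with no methoxy group involved, raises the number (a 7.5-fold higher number from compound 3 to compound 4 (0.88 log units; beyond the scatter)). Nitro in place of methoxy on an aromatic carbon gives a smaller change (a 2.5-fold lower number from compound 1 to compound 4 (0.39 log units; beyond the scatter)), so compound 3, with its pyridin-4-yl ring, keeps a lower number than either of these two substituted phenyl compounds. No measurement at hand explains these steps.

Still open, from the compounds shown here alone, is whether an amine or a carboxylic acid in place of the nitro group would bring the number closer to that of compound 3. Also open, going by these compounds, is whether a pyridin-3-yl ring would match pyridin-4-yl.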